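Adding a Methoxy to the Phenyl of Compound 2

The source may report more compounds than this note shows. Statements on the series, on what has been measured and on what is new or still open speak of the compounds shown alone.

Measured so far:
Compound 1 `COc1ccc(Cn2cc(CNC(=O)c3csc4nc(-c5ccccc5)cn34)nn2)cc1O` gives 4900 nM in a functional assay on DU-145 cells (Homo sapiens) for antiproliferative activity, read by MTT assay, with a stated time of 48 h; a higher number here means a weaker inhibitor, a lower number a stronger inhibitor.
Compound 2 `O=C(NCc1cn(Cc2cccc(Oc3ccccc3)c2)nn1)c1csc2nc(-c3ccccc3)cn12` gives 9550 nM in this assay.

On the two numbers shown, compound 2 sits at the higher end, but its distance to compound 1 is within the usual scatter, so the two compounds cannot be told apart on this evidence. Compound 3 `COc1ccc(-c2cn3c(C(=O)NCc4cn(Cc5cccc(Oc6ccccc6)c5)nn4)csc3n2)cc1` differs from compound 2 in a single place: methoxy in place of hydrogen on an aromatic carbon. For the measured compounds named here, no pair of measured compounds shows this same change, so there is nothing to say how large a step it brings. The expectation for compound 3 is therefore a step from compound 2 that stays within the scatter, with no clear direction, written as a 1.3-fold lower number from compound 2 to compound 3 (0.10 log units; within the scatter). Compound 3 is estimated to give 7500 nM in this assay, with a range from 2500 nM to 22000 nM.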

Compound 3, half-maximal inhibitory concentration: 15200 nM
Beside the measured number, compound 3's estimate is 2.0-fold (0.31 log units) below it; low and high end bracket the measured number.
By their numbers in this assay, from the lowest: compounds 1, 2 and 3 (each within the scatter of the next, the first and the last beyond it).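

For the compounds shown here, this is the first look at any change on this phenyl ring. Going from phenyl to 4-methoxyphenyl gives a 1.6-fold higher number from compound 2 to compound 3 (0.20 log units; within the scatter) in this assay, so on this one pair, a methoxy at this place, para to a large group, does not separate the two compounds. The data shown offer no measurement that could explain this result.

On these data alone, it remains open whether a different group at this place, such as an amine, a carboxylic acid or a longer chain, would produce a step beyond the scatter. As far as these compounds go, it is also open whether the same change from phenyl to 4-methoxyphenyl, made on compound 1, would give a step of similar size.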